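The compounds below may be only part of what the source reports. "The series", "measured", "known", "first", "only" and "open" are said of these compounds alone.

In an ADME assay on L132 cells (Homo sapiens) for cytotoxicity, read by MTT assay, with a stated time of 72 h (a lower number here means a stronger inhibitor, a higher number a weaker inhibitor), compound 1 `C=CCOc1cc(C2=C(c3cc(OC)c(OC)c(OC)c3)C(=O)C(O)C2)ccc1OC` gives > 100 ug/mL, and this is a limit, not a number. Compound 3 `COc1ccc(C2=C(c3cc(OC)c(OC)c(OC)c3)CC(O)C2=O)cc1[N+](=O)[O-]` gives > 100 ug/mL, which is also a limit. Compound 2 `COc1ccc(OC)c(C2=C(c3cc(OC)c(OC)c(OC)c3)C(=O)CC2O[SiH2]C(C)(C)C)c1` gives a true number, 100 ug/mL. On these data alone, compound 1 therefore stands at the limit of > 100 ug/mL in this assay, at which 2 of the 3 values shown sit, so its exact value is unknown.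

Compound 4 `COc1ccc(C2=C(c3cc(OC)c(OC)c(OC)c3)C(=O)C(O)C2)cc1Cl` has not yet been measured. It differs from compound 1 in one place: chloro in place of allyloxy on an aromatic carbon. Put simply, chloro takes the place of allyloxy on an aromatic carbon, ortho to a methoxy group. Among the compounds with values here, no pair of tested compounds differs in just one place, so no measured step shows what this swap does.

With nothing to suggest a shift in either direction, no change beyond the usual scatter is expected in this assay. Within the data shown here, the only true number to lean on is that of compound 2, at 100 ug/mL. The expected size of the change is a number no higher from compound 1 to compound 4 (the limit leaves the size open). The reading for compound 4 may well turn out to be a limit too. For compound 4 the estimated value is 100 ug/mL, with an expected range from 40 ug/mL to 200 ug/mL.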

Compound 4, half-maximal inhibitory concentration: < 1 ug/mL
Compound 4: no number, only a limit (the forecaster's own chance of this, stated with the estimate: 60%); at least 100-fold (2.00 log units) between middle value and limit.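

In this assay, within the data shown here, the single change of chloro in place of allyloxy on an aromatic carbon, ortho to a methoxy group, gives an at least 100-fold lower number from compound 1 to compound 4 (2.00 log units; beyond the scatter). Compound 4 gives < 1 ug/mL, which is a limit and not a number, and the other end of the step is a limit too, so the step has a floor but no exact size. The earlier compounds shown here contained no pair differing in one place and so could not show how much this position matters, whereas this pair shows that the group on this carbon can, with the rest of compound 1 unchanged, decide whether the cells are barely affected or strongly affected.

This one pair cannot separate the gain from having chloro from the loss of allyloxy, since both happen in the same swap, and a true number for compound 4 would need lower concentrations than this limit reflects. Also open, on these data alone, is what other groups on this carbon would do, such as bromo, a small amine, or a plain hydroxyl, and whether the effect depends on the neighbouring methoxy group.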